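The source may report more compounds than this note shows. Statements on the series, on what has been measured and on what is new or still open speak of the compounds shown alone.

Compound 1 `COc1ccc(C(=O)/C=C/c2ccc(N(c3ccccc3)c3ccccc3)cc2)c2c1C=CC(C)(C)O2`: > 10000 nM
Compound 2 `COc1ccc(C(=O)/C=C/c2ccc(N3CCCC3)cc2)c2c1C=CC(C)(C)O2`: 4740 nM

In a functional assay on HepG2 cells (Homo sapiens) for antiproliferative activity, read by MTT assay, with a stated time of 24 h (on this read-out lower numbers stand for stronger inhibition and higher numbers for weaker inhibition), compound 1 gives > 10000 nM, which is a limit of the assay and not a number. Compound 2 gives 4740 nM in this assay, the only number shown here. The other value shown sits at the limit of > 10000 nM in this assay, at which 1 of the 2 values shown sits. Compound 3 `COc1ccc(C(=O)/C=C/c2ccc(O)cc2)c2c1C=CC(C)(C)O2` carries hydroxy in place of pyrrolidin-1-yl on an aromatic carbon. Among the measured compounds shown here, no measured step between two compounds bears on this change, so the expected 1.3-fold higher number from compound 2 to compound 3 (0.10 log units; within the scatter) in this assay is none beyond the usual scatter. Compound 3 is therefore estimated at 6000 nM in this assay, within a range from 2000 nM to 20000 nM.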

Compound 3, half-maximal inhibitory concentration: > 10000 nM
Compound 3 gave a limit, no number; the forecaster's own chance of this, stated with the estimate: 30%; middle value at least 1.6-fold (0.22 log units) from the limit.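

Among the compounds shown here, compound 3 gives the first measured step at this position: in this assay, hydroxy in place of pyrrolidin-1-yl, para to a large group, gives an at least 2.1-fold higher number from compound 2 to compound 3 (0.32 log units; beyond the scatter). For the compounds shown here, the measurable number of compound 2 is lost with this change, and pyrrolidin-1-yl remains the only group here that has one. The reading for compound 3 is a limit of the assay and not a number: the limit of > 10000 nM in this assay, at which 2 of the 3 values shown sit.

As far as these compounds go, it remains open how far past that limit compound 3 lies, and whether a dimethylamino group or a piperidine ring here would keep the number of compound 2.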